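Propylcarbamoyl on compound 1: expected growth-inhibition step

The compounds below may be only part of what the source reports. "The series", "measured", "known", "first", "only" and "open" are said of these compounds alone.

Of the compounds shown here, two have numbers so far in a functional assay on Huh-7 cells (Homo sapiens) for antiproliferative activity, read by CCK-8 assay, with a stated time of 72 h (on this read-out lower numbers stand for stronger inhibition of growth and higher numbers for weaker inhibition of growth), on Huh-7 cells. Compound 1 (`CC[C@@H]1C(=O)N(C)c2cnc(-n3ccc4ccccc43)nc2N1C1CCCC1`) gives 4690 nM as the higher of the two numbers. Compound 2 (`CC[C@@H]1C(=O)N(C)c2cnc(Nc3ccc(S(=O)(=O)NCCCO)cc3)nc2N1C1CCCC1`) gives 262 nM as a lower number, and the gap lies beyond the usual scatter. Compound 1 therefore stands at the weaker end of this small set.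

Compound 3 (`CCCNC(=O)c1ccc2c(ccn2-c2ncc3c(n2)N(C2CCCC2)[C@H](CC)C(=O)N3C)c1`) keeps the core of compound 1 and carries propylcarbamoyl in place of hydrogen on an aromatic carbon. Among the measured compounds shown here, no measured pair isolates this change, so the expectation is tentative. For the measured compounds named here, the only guide is that compound 2 reaches 262 nM in the series, which leaves room below compound 1. A moderate move towards stronger inhibition of growth is expected in this assay and would lie just beyond the scatter, though a result within the scatter remains possible. The estimated change is a 3.1-fold lower number from compound 1 to compound 3 (0.50 log units; beyond the scatter) in this direction. Compound 3 is expected at 1500 nM with an estimated range from 400 nM to 5500 nM as the likely span.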

Compound 3, concentration for 50% growth inhibition: 689 nM
The estimate for compound 3 lay 2.2-fold (0.34 log units) above the measured number; low and high end bracket the measured number.
By their numbers in this assay, from the lowest: compound 2; then compound 3; then compound 1.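

In this assay, among the compounds shown here, propylcarbamoyl in place of hydrogen on an aromatic carbon of the six-membered aromatic ring of carbon only gives a 6.8-fold lower number from compound 1 to compound 3 (0.83 log units; beyond the scatter) as the first single-place step, modest in size but beyond the scatter. This position on the core of compound 1 therefore accepts a substituent of 6 heavy atoms with no loss of growth inhibition, and the change moves the number towards stronger inhibition of growth. No measurement bears on the origin of this step.

The single substituent at this one position does not separate the parts played by the carbonyl, the amide hydrogen and the propyl chain, and it does not show whether the step depends on the place on the ring. On these data alone, it remains open whether a methylcarbamoyl group, a longer butylcarbamoyl chain, a carboxylic acid or a dimethylamino group on the same aromatic carbon would keep, extend or lose the step.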